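The compounds below may be only part of what the source reports. "The series", "measured", "known", "first", "only" and "open" are said of these compounds alone.

In an ADME assay on BaF3 cells (Mus musculus) for antiproliferative activity, read by CCK-8 assay, with a stated time of 72 h (a lower number here means a stronger inhibitor of growth, a higher number a weaker inhibitor of growth), three compounds have been measured. Compound 1 `O=C(CCSc1ccc2c(/C=C/c3ccccn3)n[nH]c2c1)Nc1ccc(CN2CCCC2)c(C(F)(F)F)c1` gives 4000 nM, compound 2 `O=C(NCCCSc1ccc2c(/C=C/c3ccccn3)n[nH]c2c1)c1cccc(C(F)(F)F)c1` gives 980 nM, and compound 3 `CN1CCN(Cc2ccc(NC(=O)CCSc3ccc4c(-c5ccccc5)n[nH]c4c3)cc2C(F)(F)F)CC1` gives 600 nM. Compound 3 thus lies within the scatter of compound 2, while compound 1 has a number beyond the scatter above it. Compound 4 `CN1CCN(Cc2ccc(NC(=O)CCSc3ccc4c(-c5cccnc5)n[nH]c4c3)cc2C(F)(F)F)CC1` differs from compound 3 in one place: pyridin-3-yl in place of phenyl on an aromatic carbon. Within the data shown here, no measured pair shows this change, so any expectation in this assay is tentative. A small shift towards a lower number, within the scatter, is expected: the estimated step is a 1.3-fold lower number from compound 3 to compound 4 (0.12 log units; within the scatter). Compound 4 is estimated at 450 nM, with an expected range of 150 nM to 1500 nM.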

Compound 4, concentration for 50% growth inhibition: 2650 nM
Compound 4: the middle estimate sits 5.9-fold (0.77 log units) below what was measured; the whole stated range lies below it.
By their numbers in this assay, from the lowest: compounds 3 and 2 (each within the scatter of the next); then compounds 4 and 1 (each within the scatter of the next).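

In this assay, among these compounds, the first single-place comparison at this position shows that replacing phenyl with pyridin-3-yl on the aromatic carbon gives a 4.4-fold higher number from compound 3 to compound 4 (0.65 log units; beyond the scatter), a step beyond the scatter. Within this pair, the aryl group at this position therefore matters, and a single ring nitrogen in place of a ring carbon is enough to weaken growth inhibition. Nothing available here accounts for the loss. On these data alone, it remains open whether pyridin-4-yl or pyridin-2-yl would cost as much as pyridin-3-yl. As far as these compounds go, how a phenyl ring carrying a methoxy group or a fluorine would compare is also open.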